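The compounds below may be only part of what the source reports. "The series", "measured", "known", "first", "only" and "open" are said of these compounds alone.

Measured compounds:
- compound 1, `Cc1ccc2nc(Cl)c(/C=N/n3cc(-c4ccc(Cl)cc4)nc3N)cc2c1`, 38500 nM
- compound 2, `Cc1ccc2nc(Cl)c(/C=N/n3cc(-c4ccc5ccccc5c4)nc3N)cc2c1`, 11400 nM

In an ADME assay on HUVEC cells (Homo sapiens) for cytotoxicity, read by MTT assay, with a stated time of 48 h (on this read-out lower numbers stand for stronger inhibition and higher numbers for weaker inhibition), compound 2 gives the lowest of the two numbers; its nearest neighbour is compound 1, and the step of a 3.4-fold lower number from compound 1 to compound 2 (0.53 log units; beyond the scatter) separates them. That step is the only one that bears on the change now considered: a smaller aromatic group (4-chlorophenyl) gave a higher number than the larger naphthalen-2-yl.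

Compound 3, `Cc1ccc2nc(Cl)c(/C=N/n3cc(-c4cccs4)nc3N)cc2c1`, differs from compound 2 by thiophen-2-yl in place of naphthalen-2-yl on an aromatic carbon. Thiophen-2-yl is smaller still than 4-chlorophenyl. Going by the values given here, on the single step available, the direction of the change in compound 3 is expected to be toward a higher number in this assay, of roughly the size seen between compound 1 and compound 2, so the estimated step is a 3.1-fold higher number from compound 2 to compound 3 (0.49 log units; beyond the scatter). For compound 3 the expected value in this assay is therefore 35000 nM, with a range from 12000 nM to 100000 nM.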

Compound 3, half-maximal inhibitory concentration: 38000 nM
Beside the measured number, compound 3's estimate is 1.1-fold (0.04 log units) below it, and the stated range covers the measured number.
By their numbers in this assay, from the lowest: compound 2; then compounds 3 and 1 (each within the scatter of the next).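

In this assay, the step of a 3.3-fold higher number from compound 2 to compound 3 (0.52 log units; beyond the scatter) shows that replacing naphthalen-2-yl, with its two six-membered aromatic rings, by thiophen-2-yl, with one five-membered aromatic ring, shifts the number beyond the scatter. The step of a 1.0-fold lower number from compound 1 to compound 3 (0.01 log units; within the scatter) lies within the scatter, so thiophen-2-yl and 4-chlorophenyl cannot be told apart here, even though they are different aromatic groups. Among these three compounds, only compound 2 stands apart, so the numbers do not fall in steady steps as the group grows.

Nothing available explains this pattern. Going by these compounds, it also remains open whether the low number of compound 2 is specific to naphthalen-2-yl, and how an amine, a carboxylic acid or a longer chain at this position would read.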